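The compounds below may be only part of what the source reports. "The series", "measured", "known", "first", "only" and "open" are said of these compounds alone.

Working notes on the series. In a functional assay on A549 cells (Homo sapiens) for inhibition, read by MTT assay, with a stated time of 72 h (a higher number here means a weaker inhibitor, a lower number a stronger inhibitor), compound 1 (`COc1cc2c(Oc3ccc(NC(=O)c4nn(-c5ccccc5C)cc(C)c4=O)cc3)ccnc2cc1OCC(=O)NO`) gives 5980 nM, compound 2 (`COc1cc2c(Oc3ccc(NC(=O)c4nn(-c5ccccc5C)cc(C)c4=O)cc3F)ccnc2cc1OCCCC(=O)NO`) gives 2090 nM and compound 3 (`COc1cc2c(Oc3ccc(NC(=O)c4nn(-c5ccccc5F)cc(C)c4=O)cc3)ccnc2cc1OCCCC(=O)NO`) gives 3920 nM. The number for compound 3 lies within the scatter of the numbers for both compound 1 and compound 2.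

Compound 4 (`COc1cc2c(Oc3ccc(NC(=O)c4nn(-c5ccccc5C)cc(C)c4=O)cc3)ccnc2cc1OCCCC(=O)NO`) follows from compound 3 with methyl in place of fluoro on an aromatic carbon, that is, 2-fluorophenyl to 2-methylphenyl: methyl in place of fluoro on an aromatic carbon. Among the measured compounds shown here, no measured pair differs in one place only, so this exchange has no direct precedent in the data. Compound 1 at 5980 nM and compound 2 at 2090 nM both carry 2-methylphenyl, and each stands within the scatter of compound 3 at 3920 nM. On that basis, no change beyond the scatter is expected in this assay, in either direction. The expected step is a 1.3-fold lower number from compound 3 to compound 4 (0.12 log units; within the scatter). For compound 4 the estimated value is 3000 nM, with an expected range of 1400 nM to 6300 nM.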

Compound 4, half-maximal inhibitory concentration: 4460 nM
Estimate against measurement, compound 4: 1.5-fold (0.17 log units) below; the range from low to high includes it.
By their numbers in this assay, from the lowest: compounds 2, 3, 4 and 1 (each within the scatter of the next, the first and the last beyond it).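

In this assay, among the compounds shown here, 2-fluorophenyl to 2-methylphenyl gives a 1.1-fold higher number from compound 3 to compound 4 (0.06 log units; within the scatter) and so does not separate methyl from fluoro on this aromatic carbon, a first direct reading at this position; 2-(hydroxycarbamoyl)ethyl in place of hydroxycarbamoyl gives a 1.3-fold lower number from compound 1 to compound 4 (0.13 log units; within the scatter) and likewise leaves the two chains unseparated. Loss of a fluoro group, at a different place from the 2-fluorophenyl group, gives a 2.1-fold higher number from compound 2 to compound 4 (0.33 log units; beyond the scatter) as a modest step, and it is the only one of the three beyond the scatter. No measurement at hand bears on the reason for any of these results.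

From the compounds shown here alone, whether hydrogen, chloro or methoxy on the 2-position of this phenyl ring would separate from methyl and fluoro remains open. Also open, going by these compounds, is how a longer chain carrying the hydroxycarbamoyl group, or an amine or carboxylic acid in its place, would read in this assay.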